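This account rests on a few compounds, and the source may have more. Where it says the series, first, only, none or still open, it means among the compounds named here.

Compound 1 `O=C(NCc1cc(Cl)ccc1-n1cnnn1)[C@@H]1[C@H]2C[C@H]2CN1C(=O)[C@H](O)CC1CC1` and compound 2 `O=C(NCc1cc(Cl)ccc1-n1cnnn1)[C@@H]1[C@H]2C[C@H]2CN1C(=O)[C@H](O)Cc1ccccc1` share one core and differ in a single place. In an ADME assay on liver for metabolic stability, with Liver microsome (Homo sapiens) as the target, read by LC-MS, using microsomes (a higher number here means faster removal of the compound, a lower number slower removal), compound 1 gives < 14 mL.min-1.g-1, which is a limit of the assay rather than a number. In this assay compound 2 gives 96 mL.min-1.g-1, the only number shown among the two values. The other value, that of compound 1, is the limit of < 14 mL.min-1.g-1 in this assay, at which 1 of the 2 values shown sits. Among the compounds with values here, the only measured step is an at least 6.8-fold higher number from compound 1 to compound 2 (0.83 log units; beyond the scatter), in which a phenyl replaced a cyclopropyl on the chain carbon carrying the hydroxyl. Compound 3 `CC(C)(C)[C@@H](O)C(=O)N1C[C@@H]2C[C@@H]2[C@H]1C(=O)NCc1cc(Cl)ccc1-n1cnnn1` has not yet been measured; it differs from compound 2 by tert-butyl in place of benzyl on a saturated chain carbon bound to a carbonyl carbon and an oxygen on a saturated carbon. This change takes the aromatic ring away again, running counter to the measured step, so a lower number is expected for compound 3, possibly at the limit itself. The expected step is a 4.8-fold lower number from compound 2 to compound 3 (0.68 log units; beyond the scatter). For compound 3 the estimate is 20 mL.min-1.g-1, between 9 mL.min-1.g-1 and 50 mL.min-1.g-1.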

Compound 3, intrinsic clearance in microsomes: < 15 mL.min-1.g-1
Compound 3: no number, only a limit; the forecaster's own chance of this, stated with the estimate: 35%; middle value at least 1.3-fold (0.12 log units) from the limit.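

In this assay, tert-butyl in place of benzyl on this chain carbon gives an at least 6.4-fold lower number from compound 2 to compound 3 (0.80 log units; beyond the scatter), so the high number now stands apart from two compounds rather than one, and compound 2 is the only one of the three with an aromatic ring at this place. Compound 3 gives a limit of the assay rather than a number: the limit of < 15 mL.min-1.g-1 in this assay, at which 1 of the 3 values shown sits. The step from compound 1 to compound 3 cannot be read, so cyclopropylmethyl and tert-butyl cannot be placed in order.

With benzyl as the only group of its kind here, the compounds shown do not separate the aromatic ring from the larger number of carbons, a question that cyclohexylmethyl at this place would address. Where a pyridylmethyl group, which carries a ring nitrogen, would fall also remains open.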